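The source may hold more compounds than are shown below. What is called first, only, known or untested is meant among the compounds shown, and "the series" means these compounds.

Among the measured compounds shown here, compound 2 `Cc1cccnc1N1CCN(C(=O)Nc2ccc(C(C)C)cc2)CC1` is one of two compounds measured in a functional assay on HEK293 cells for antagonist activity at transient receptor potential cation channel subfamily V member 1 (Rattus norvegicus) (a higher number here means a weaker inhibitor, a lower number a stronger inhibitor), and in this assay compound 2 gives 25.3 nM. That is the higher of the two numbers; the other, compound 1 `CC(C)(C)c1ccc(NC(=O)N2CCN(c3ncccc3C(F)(F)F)CC2)cc1`, in this assay gives 11.3 nM, a lower number, so compound 1 is the stronger inhibitor of the pair. Compound 3 `CC(C)c1ccc(NC(=O)N2CCN(c3ncccc3C=O)CC2)cc1` has not yet been measured. The change from compound 2 to compound 3 is formyl in place of methyl on an aromatic carbon: one small group is swapped for another that brings a hydrogen-bond acceptor. For the measured compounds named here, no measured pair shows this exact swap, so its effect cannot be read from the data. The expectation is a small upward move in the number, a 1.6-fold higher number from compound 2 to compound 3 (0.20 log units; within the scatter), though a result within the scatter would not be surprising. Compound 3 is therefore estimated at 40 nM, with a range from 15 nM to 110 nM.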

Compound 3, half-maximal inhibitory concentration: 201 nM
The estimate for compound 3 lay 5.0-fold (0.70 log units) below the measured number; the measured number lies above the stated range.
By their numbers in this assay, from the lowest: compound 1; then compound 2; then compound 3.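

In this assay, the change from 3-methylpyridin-2-yl to 3-formylpyridin-2-yl gives a 7.9-fold higher number from compound 2 to compound 3 (0.90 log units; beyond the scatter), so compound 3 is a clearly weaker inhibitor than compound 2. Among the compounds shown here, this is the first measured sign that this aromatic carbon, two atoms from the ring nitrogen, does not treat all small groups alike: swapping one small group for another that brings a hydrogen-bond acceptor is enough to lose inhibition. Nothing available explains the loss.

The compounds shown leave open whether the loss belongs to the formyl group itself or would come with any hydrogen-bond acceptor on this carbon. A nitrile, a methoxy or a hydroxymethyl group at the same place would help separate these two readings, and an amine would show how a different kind of group fares there.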